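Swapping acetyl for cyano on a vinyl sulfone

This account rests on a few compounds, and the source may have more. Where it says the series, first, only, none or still open, it means among the compounds named here.

Of the compounds shown here, three built on a shared indole core have been tested in a functional assay on RXF 393 cells (Homo sapiens) for inhibition, read by sulforhodamine B assay, with a stated time of 48 h; on this read-out lower numbers stand for stronger inhibition of growth and higher numbers for weaker inhibition of growth. Compound 1 `CCOC(=O)C(=Cc1c(-c2ccccc2)[nH]c2ccccc12)C(=O)OCC` gives 3700 nM, compound 2 `CC(=O)/C(=C\c1c(-c2ccccc2)[nH]c2ccccc12)S(=O)(=O)c1ccccc1` gives 1300 nM, and compound 3 `COc1ccc(-c2[nH]c3ccc(OC)cc3c2C=C(C#N)C#N)cc1` gives 5500 nM. Compound 2 stands lowest of the three, and both gaps run beyond the scatter: compound 1 sits higher, and compound 3 sits higher still. Each of these compounds differs from the others in more than one place. Within the data shown here, no single step between measured compounds can be separated out, and the readings show only where each one stands.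

Compound 4 `N#C/C(=C\c1c(-c2ccccc2)[nH]c2ccccc12)S(=O)(=O)c1ccccc1` is the next compound to be tested in this assay. It differs from compound 2 in one place: cyano in place of acetyl on a double-bonded chain carbon bound to a double-bonded chain carbon and a sulfonyl sulfur. Among the measured compounds shown here, with no measured step of this kind to lean on, the expectation for compound 4 is a change that stays within the scatter, leaning if anything towards a slightly higher number, given that compound 3, which also carries cyano on its chain, gives 5500 nM. For compound 4 the estimate is 1800 nM, with a range from 600 nM to 5500 nM, which corresponds to an expected step of a 1.4-fold higher number from compound 2 to compound 4 (0.14 log units; within the scatter).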

Compound 4, concentration for 50% growth inhibition: 3600 nM
For compound 4 the middle estimate is 2.0-fold (0.30 log units) below the measured one; measured number inside the range.
By their numbers in this assay, from the lowest: compound 2; then compounds 4, 1 and 3 (each within the scatter of the next).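

In this assay, this position now has its first measured step: cyano in place of acetyl on a double-bonded chain carbon bound to a double-bonded chain carbon and a sulfonyl sulfur gives a 2.8-fold higher number from compound 2 to compound 4 (0.44 log units; beyond the scatter). The earlier compounds shown here each differed from one another in more than one place, so they could not show that this single group alone moves the number beyond the scatter, with acetyl on the lower side of the pair. The two groups match in hydrogen-bond donors and acceptors and differ in heavy atoms and in bond type, but no measurement given here explains why the number moves.

The compounds shown leave open how a carboxylic acid, a primary amide or a longer acyl chain such as propanoyl would compare with acetyl at this place, and so whether acetyl is unusual or cyano is. They also leave open whether the same swap gives a step of similar size when the sulfonyl-bound phenyl is replaced by another group, such as methyl, or when the shared core carries methoxy groups.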